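This account rests on a few compounds, and the source may have more. Where it says the series, first, only, none or still open, it means among the compounds named here.

Measured so far in an assay for inhibition of Aromatase (Homo sapiens), at 37 degrees C, at pH 7.0; on this read-out higher numbers stand for weaker inhibition and lower numbers for stronger inhibition:
- compound 1, `COc1ccc2c(=O)c(-c3ccccc3)c(-n3ccnc3)oc2c1`, gives 680 nM
- compound 2, `COc1ccc(-c2c(-n3ccnc3)oc3cc(OC)ccc3c2=O)cc1`, gives 1820 nM
- compound 3, `O=c1c(-c2ccccc2)c(-n2ccnc2)oc2cc(OCc3ccccc3)ccc12`, gives 250 nM

Compound 3 has the lowest number of the three in this assay, and its steps to compound 1 and compound 2 are both beyond the scatter, so it is the strongest inhibitor measured here. Compound 4, `COc1ccc(-c2c(-n3ccnc3)oc3cc(OCc4ccccc4)ccc3c2=O)cc1`, is not yet measured. It differs from compound 3 by methoxy in place of hydrogen on an aromatic carbon. For the measured compounds named here, one measured step bears directly on this: a 2.7-fold higher number from compound 1 to compound 2 (0.43 log units; beyond the scatter), the same change carried out on compound 1 rather than on compound 3. If that step repeats, compound 4 is expected to give a modestly higher number than compound 3, estimated as a 2.7-fold higher number from compound 3 to compound 4 (0.43 log units; beyond the scatter). Compound 4 is therefore estimated at 680 nM in this assay, with a likely range from 350 nM to 1400 nM.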

Compound 4, inhibition constant: 4400 nM
Beside the measured number, compound 4's estimate is 6.5-fold (0.81 log units) below it, outside the stated range (above it).
By their numbers in this assay, from the lowest: compound 3; then compound 1; then compound 2; then compound 4.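

Going from phenyl to 4-methoxyphenyl gives an 18-fold higher number from compound 3 to compound 4 (1.25 log units; beyond the scatter), so in this assay this change has no fixed size, and its effect depends on the rest of the molecule: the same change on two cores in this assay, a 2.7-fold higher number (0.43 log units; beyond the scatter) from compound 1 to compound 2 and an 18-fold higher number (1.25 log units; beyond the scatter) from compound 3 to compound 4, 6.6-fold (0.82 log units) apart, beyond the scatter of two such steps. The phenyl added on the chain also reverses direction once the methoxy is present, giving a 2.4-fold higher number from compound 2 to compound 4 (0.38 log units; beyond the scatter): the same change on two cores in this assay, a 2.7-fold lower number (0.43 log units; beyond the scatter) from compound 1 to compound 3 and a 2.4-fold higher number (0.38 log units; beyond the scatter) from compound 2 to compound 4, 6.6-fold (0.82 log units) apart, beyond the scatter of two such steps. The two changes therefore do not simply add up across these four compounds.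

On these data alone, it remains open whether a hydroxyl or a chlorine on that ring carbon would depend on the rest of the molecule in the same way. These numbers do not show what lies behind the dependence.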